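Oxalamide tail swap on a triarylethylene scaffold

The source may hold more compounds than are shown below. What is called first, only, known or untested is meant among the compounds shown, and "the series" means these compounds.

Measured compounds:
Compound 1, `COc1ccc(/C(=C(/CCCl)c2ccccc2)c2ccccc2)cc1`, gives > 50000 nM in a functional assay on MDA-MB-231 cells (Homo sapiens) for cytotoxicity, read by MTT assay, with a stated time of 72 h; on this read-out lower numbers stand for stronger inhibition and higher numbers for weaker inhibition; this is a limit of the assay and not a number.
Compound 2, `COc1ccc(/C(=C(/CCN)c2ccccc2)c2ccccc2)cc1`, gives 11400 nM in this assay.
Compound 3, `COc1ccc(/C(=C(/CCNC(=O)C(=O)NCc2ccccc2)c2ccccc2)c2ccccc2)cc1`, gives 11500 nM in this assay.

Compound 3 sits highest of the two real numbers, and its nearest neighbour is compound 2; the two are within the scatter of each other, so neither can be called the more potent. Among the compounds with values here, the one clear step is an at least 4.3-fold lower number from compound 1 to compound 2 (0.64 log units; beyond the scatter), where compound 1 only set (the limit of > 50000 nM in this assay, at which 1 of the 3 values shown sits). The second step, a 1.0-fold higher number from compound 2 to compound 3 (0.00 log units; within the scatter), shows that hanging a large benzyl-bearing oxalamide tail on the amine nitrogen left the number where it was.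

Compound 4, `COc1ccc(/C(=C(/CCNC(=O)C(=O)NC2CCCCC2)c2ccccc2)c2ccccc2)cc1`, is the next compound to test. It differs from compound 3 by cyclohexyl in place of benzyl on an amide-type nitrogen. Within the data shown here, the only measured step that touches this tail is the one from compound 2 to compound 3, and it was flat; nothing measured here speaks to swapping one ring for another at the far end of the tail. The step of a 1.0-fold lower number from compound 3 to compound 4 (0.02 log units; within the scatter) is therefore expected to stay within the scatter. Compound 4 is estimated at 11000 nM, with a range from 5000 nM to 25000 nM.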

Compound 4, half-maximal inhibitory concentration: 12200 nM
The estimate for compound 4 lay 1.1-fold (0.04 log units) below the measured number; the range from low to high includes it.
By their numbers in this assay, from the lowest: compounds 2, 3 and 4 (each within the scatter of the next). At a limit, above all of these: compound 1.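

Swapping the aromatic benzyl ring for the non-aromatic cyclohexyl ring on the amide-type nitrogen, at the far end of the tail, gives a 1.1-fold higher number from compound 3 to compound 4 (0.03 log units; within the scatter) in this assay, so at this position the two rings cannot be told apart by their numbers. The second tail also stays level with the free amine, with a 1.1-fold higher number from compound 2 to compound 4 (0.03 log units; within the scatter), which means that two oxalamide tails with different end rings now match the unsubstituted amine, and the flat result no longer rests on compound 3 alone. The only step beyond the scatter remains an at least 4.0-fold lower number from compound 1 to compound 4 (0.61 log units; beyond the scatter), and it gives only a minimum size, since compound 1 stands at a limit of the assay and not at a number: the limit of > 50000 nM in this assay, at which 1 of the 4 values shown sits.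

As far as these compounds go, it remains open whether a tail ending in a carboxylic acid or a dimethylamino group, or a tail with a longer chain leading to the cyclohexyl ring, would move the number beyond the scatter. Also open, from the compounds shown here alone, is what a hydroxyl in place of the methoxy group on the shared core would do to compound 4.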